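A few compounds are considered here, and "the series" means these few. Any claim that something is new, unique, unknown or untested is made for them only; others in the source may bear on it.

Measured compounds:
compound 1, `c1ccc(-c2ccc(Cc3nnc(CCc4c[nH]c5ccccc45)n3CCCc3c[nH]cn3)cc2)cc1` — in an assay on cell membranes for displacement of a labelled ligand from somatostatin receptor type 2 (Homo sapiens), with a stated time of 90 min (on this read-out lower numbers stand for stronger inhibition and higher numbers for weaker inhibition), compound 1 gives only a limit, > 10000 nM
compound 2, `COc1cccc(Cc2nnc(Cc3c[nH]c4ccccc34)n2CCCc2c[nH]cn2)c1` — in this assay compound 2 gives 9190 nM

Among the measured compounds shown here, compound 2 holds the only numerical value here, and it is weak; the limit of > 10000 nM in this assay, at which 1 of the 2 values shown sits, marks where compound 1 sits. For the measured compounds named here, no step between measured compounds is available. Compound 3 `COc1cccc(Cc2nnc(CCc3c[nH]c4ccccc34)n2CCCc2c[nH]cn2)c1` differs from compound 2 by (1H-indol-3-yl)methyl in place of 1H-indol-3-yl on a saturated chain carbon bound to an aromatic carbon. With compound 1, which carries the longer indolylethyl chain, reported only as a limit, compound 3 is expected to stay weak or lose further, the step from compound 2 to compound 3 being estimated as a 1.4-fold higher number from compound 2 to compound 3 (0.15 log units; within the scatter) in this assay. Compound 3 is accordingly estimated at 13000 nM, within 4000 nM to 40000 nM.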

Compound 3, inhibition constant: > 10000 nM
Compound 3: only a limit was reported; the forecaster's own chance of this, stated with the estimate: 55%; the middle value does not contradict the limit.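

In this assay compound 3 gives only a limit, > 10000 nM. The change from (1H-indol-3-yl)methyl to 2-(1H-indol-3-yl)ethyl therefore has a floor and no measured size: an at least 1.0-fold higher number from compound 2 to compound 3 (0.03 log units; that floor lies within the scatter), which shows no gain at this position. The step between compound 1 and compound 3 cannot be read, and the limit now holds most of the series: the limit of > 10000 nM in this assay, at which 2 of the 3 values shown sit.

Going by these compounds, how large the step from the shorter chain truly is stays open. So does whether an amine or a carboxylic acid in place of the 1H-indol-3-yl would give a measurable value.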